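Truncating the pyrazolylamino group of compound 3

The source may report more compounds than this note shows. Statements on the series, on what has been measured and on what is new or still open speak of the compounds shown alone.

Compound 3 `C[C@@H]1CCCN1c1c(C#N)c2c(N)nc(Nc3cn(C)nc3Cl)nc2n1C` gives 21 nM in an assay on isolated protein for inhibition of Leucine-rich repeat serine/threonine-protein kinase 2 variant G2019S (Homo sapiens), read by TR-FRET and LanthaScreen, with stated times of 50 min and 30 min, in the presence of a further agent that is not named here (on this read-out lower numbers stand for stronger inhibition and higher numbers for weaker inhibition), the lowest of the three numbers. Compound 2 `Cc1nn(C2COC2)cc1Nc1nc(N)c2c(C#N)c(N3CCC[C@H]3C)n(C)c2n1` gives 25 nM in this assay, and the step of a 1.2-fold lower number from compound 2 to compound 3 (0.08 log units; within the scatter) is within the scatter. Compound 1 `Cc1c(Nc2nc(N)c3c(C#N)c(N4CCC[C@H]4C)n(C)c3n2)cnn1C` gives 43 nM in this assay; the step of a 2.0-fold lower number from compound 1 to compound 3 (0.31 log units; beyond the scatter) is modest, and the step of a 1.7-fold lower number from compound 1 to compound 2 (0.24 log units; within the scatter) is within the scatter. All three carry a substituted pyrazolyl group on the same nitrogen and differ only in the substituents on that ring. Compound 4 `C[C@@H]1CCCN1c1c(C#N)c2c(N)nc(N)nc2n1C` carries hydrogen in place of 3-chloro-1-methyl-1H-pyrazol-4-yl on a nitrogen on an aromatic ring. For the measured compounds named here, no measured step removes the ring from this nitrogen; the three steps among the pyrazoles are all small and say nothing direct about truncation to a bare amino group. The change is far larger than any measured one, so a rise in the number well beyond the scatter is expected, with the size uncertain. Compound 4 is therefore expected to give 2500 nM in this assay, within 300 nM to 20000 nM, the step of a 120-fold higher number from compound 3 to compound 4 (2.08 log units; beyond the scatter) being an estimate.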

Compound 4, half-maximal inhibitory concentration: 217 nM
Compound 4: the middle estimate sits 12-fold (1.06 log units) above what was measured; the measured number lies below the stated range.
By their numbers in this assay, from the lowest: compounds 3, 2 and 1 (each within the scatter of the next, the first and the last beyond it); then compound 4.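

In this assay, taking the substituted pyrazolyl group off this nitrogen weakens inhibition in all three pairs (a 10-fold higher number from compound 3 to compound 4 (1.01 log units; beyond the scatter); an 8.7-fold higher number from compound 2 to compound 4 (0.94 log units; beyond the scatter); a 5.0-fold higher number from compound 1 to compound 4 (0.70 log units; beyond the scatter)), whereas changes among the pyrazole substituents had moved the number far less. The bare amino group still leaves measurable inhibition, with compound 4 at (217 nM), so the pyrazole adds to the activity of the shared core but is not required for it. No measurement here accounts for the size of these steps.

Open, going by these compounds, is whether a pyrazole is needed on this nitrogen, or whether a phenyl ring, a cyclopropyl ring or a single methyl would restore the lost activity. Also open, on these data alone, is how an acetyl group on this nitrogen would compare with the free amino group of compound 4.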